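From a Dihydroxyphenyl Group to a Phenylethenyl Group

The source may hold more compounds than are shown below. What is called first, only, known or untested is meant among the compounds shown, and "the series" means these compounds.

Of the compounds shown here, three sharing one core have been measured in a functional assay (artery, Rattus norvegicus); on this read-out lower numbers stand for stronger inhibition and higher numbers for weaker inhibition. Compound 1 `O=C(/C=C/c1ccc(O)cc1)OCCOc1no[n+]([O-])c1S(=O)(=O)c1ccccc1` gives 675 nM. Compound 2 `O=C(OCCOc1no[n+]([O-])c1S(=O)(=O)c1ccccc1)c1ccc(O)c(O)c1` gives 1600 nM, and compound 3 `COc1cc(/C=C/C(=O)OCCOc2no[n+]([O-])c2S(=O)(=O)c2ccccc2)ccc1O` gives 1340 nM, so these last two cannot be told apart within the scatter. For compound 2, the only gap beyond the scatter is a 2.4-fold higher number from compound 1 to compound 2 (0.37 log units; beyond the scatter).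

Compound 4 `O=C(/C=C/c1ccccc1)OCCOc1no[n+]([O-])c1S(=O)(=O)c1ccccc1` has not yet been measured. It keeps the shared core and changes only the group on the carbonyl carbon: 2-phenylethenyl in place of 3,4-dihydroxyphenyl on a carbonyl carbon. The entering 2-phenylethenyl group resembles the 2-(4-hydroxyphenyl)ethenyl group of compound 1, so the measured swap between those two groups and the 3,4-dihydroxyphenyl group bears most directly on this change. That swap was modest, at a 2.4-fold higher number from compound 1 to compound 2 (0.37 log units; beyond the scatter). The other measured step, a 2.0-fold higher number from compound 1 to compound 3 (0.30 log units; within the scatter), stays within the scatter and adds a methoxy group to the aromatic ring. Among the compounds with values here, no measured compound carries the plain 2-phenylethenyl group, so the comparison is only partial. A small move toward a lower number is therefore expected, roughly the reverse of the first step, and the expected change is a 2.0-fold lower number from compound 2 to compound 4 (0.30 log units; within the scatter). For compound 4 the estimated value is 800 nM, with an expected range from 330 nM to 1950 nM.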

Compound 4, half-maximal inhibitory concentration: 1330 nM
The estimate for compound 4 lay 1.7-fold (0.22 log units) below the measured number, and the stated range covers the measured number.
By their numbers in this assay, from the lowest: compounds 1, 4, 3 and 2 (each within the scatter of the next, the first and the last beyond it).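

In this assay, putting 2-phenylethenyl in place of 3,4-dihydroxyphenyl on the carbonyl carbon gives a 1.2-fold lower number from compound 2 to compound 4 (0.08 log units; within the scatter) and stays within the scatter, so going from 2 hydrogen-bond donors to 0 and bringing in a double bond outside the ring leaves no readable difference here. The two other comparisons also stay within the scatter: a 2.0-fold higher number from compound 1 to compound 4 (0.29 log units; within the scatter) with hydrogen in place of hydroxy on an aromatic carbon, and a 1.0-fold lower number from compound 3 to compound 4 (0.00 log units; within the scatter) with phenyl in place of 4-hydroxy-3-methoxyphenyl, so neither change can be shown to matter on its own. Compound 4 therefore cannot be told apart from compound 1, compound 2 or compound 3, even though compound 1 and compound 2 differ beyond the scatter, and the plain 2-phenylethenyl group sides with neither end of that gap.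

From the compounds shown here alone, whether an amine or a carboxylic acid on the aromatic ring, or a longer chain in place of the 2-phenylethenyl link, would move the number beyond the scatter stays open. Nothing is available that explains these numbers.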